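The compounds below may be only part of what the source reports. "The series", "measured", "known", "first", "only" and "open" are said of these compounds alone.

Measured so far in an ADME assay on RAW264.7 cells (Mus musculus) for cytotoxicity, read by MTT assay, with a stated time of 72 h, tested at 50 uM; on this read-out higher numbers stand for a stronger effect at the one concentration tested and lower numbers for a weaker effect:

compound 1 `O=C(Cn1c(=O)oc2cc(Cl)ccc21)Nc1nc2ccccc2s1` gives 38.7%
compound 2 `O=C(Cn1c(=O)oc2cc([N+](=O)[O-])ccc21)NCc1ccccn1` gives 21.8%
compound 3 `O=C(Cn1c(=O)oc2ccccc21)NCc1cccs1` gives 23.4%

Compound 2 stands lowest of the three numbers. Its nearest neighbour is compound 3, whose value lies higher by an amount that is within the usual scatter of repeated measurements, so the two cannot be told apart on this read-out. Its furthest neighbour is compound 1, whose value lies higher by an amount beyond that scatter.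

The account follows the step from compound 2 to compound 4 `O=C(Cn1c(=O)oc2cc([N+](=O)[O-])ccc21)Nc1ccccc1`. The change is phenyl in place of (pyridin-2-yl)methyl on an amide-type nitrogen. Within the data shown here, no pair of measured compounds shows this change, so no measured step guides the expectation. The three numbers span a modest range, and nothing in them points to a large move in either direction. The step is expected to be small, likely a slight rise that stays within the scatter, as a number 6.2 percentage points higher from compound 2 to compound 4 (within the scatter). Compound 4 is therefore estimated to give 28% in this assay, with a range from 12% to 45%.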

Compound 4, a percentage reported as inhibition, at one concentration (the size of the read-out at that concentration, not a potency): 18%
Compound 4: the middle estimate sits 10 percentage points above what was measured, within the range that was stated.
By their numbers in this assay, from the lowest: compounds 4, 2 and 3 (each within the scatter of the next); then compound 1.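

In this assay, among these compounds, the step on this amide-type nitrogen reads a number 3.8 percentage points lower from compound 2 to compound 4 (within the scatter) and gives the first direct comparison at this position. Phenyl in place of (pyridin-2-yl)methyl therefore produces no change that can be told apart from the scatter, even though the change removes the ring hetero atom and the link between the ring and the nitrogen together. The data at hand give no explanation for this result.

Because both features change in the one step, the compounds shown leave open whether either alone would matter, and a benzyl group on the same nitrogen would separate them. Also open, on these data alone, is whether a longer chain, such as 2-phenylethyl, or a carboxylic acid on the phenyl ring would move the number beyond the scatter.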